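A few compounds are considered here, and "the series" means these few. Any claim that something is new, unique, unknown or untested is made for them only; others in the source may bear on it.

Measured compounds:
compound 1 `c1ccc(COc2cccc(-c3cn(C4CN5CCC4CC5)nn3)c2)cc1` — 668 nM
compound 2 `c1ccc(COc2cccc(-c3cn([C@H]4CN5CCC4CC5)nn3)c2)cc1` — 5060 nM
compound 3 `FCCCOc1cccc(-c2cn([C@H]3CN4CCC3CC4)nn2)c1` — 9010 nM

In an assay on HEK293 cells for displacement of a labelled ligand from Neuronal acetylcholine receptor; alpha4/beta2 (Homo sapiens), read by scintillation counting, with a stated time of 120 min (on this read-out higher numbers stand for weaker inhibition and lower numbers for stronger inhibition), compound 1 holds the lowest of the three numbers. The nearest is the step of a 7.6-fold higher number from compound 1 to compound 2 (0.88 log units; beyond the scatter), a difference that rests on the fact that one of compounds 1 and 2 is drawn with a defined configuration and the other without, at the place where they differ alone. The furthest is compound 3 at 9010 nM.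

Compound 4 `FCCOc1cccc(-c2cn(C3CN4CCC3CC4)nn2)c1` is not yet measured. Relative to compound 1 the change is fluoromethyl in place of phenyl on a saturated chain carbon bound to an oxygen on an aromatic ring.

Going by the values given here, two measured steps bear on this. Among the compounds with values here, the step of a 1.8-fold higher number from compound 2 to compound 3 (0.25 log units; within the scatter) swaps the same phenyl for a fluoroalkyl chain one carbon longer than the one entering compound 4, and stays within the scatter. The step of a 7.6-fold higher number from compound 1 to compound 2 (0.88 log units; beyond the scatter) concerns only the drawn configuration; compound 4, like compound 1, is drawn without one, so that step does not enter here.

On this basis the expectation is a small shift in compound 4 toward a higher number, if any, of about a 1.8-fold higher number from compound 1 to compound 4 (0.25 log units; within the scatter). Compound 4 is therefore estimated at 1200 nM, within 400 nM to 3600 nM.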

Compound 4, inhibition constant: 1960 nM
Compound 4: the middle estimate sits 1.6-fold (0.21 log units) below what was measured, and the stated range covers the measured number.
By their numbers in this assay, from the lowest: compound 1; then compound 4; then compounds 2 and 3 (each within the scatter of the next).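

In this assay, the step of a 2.9-fold higher number from compound 1 to compound 4 (0.47 log units; beyond the scatter) shows that, with both compounds drawn without a configuration, replacing phenyl with fluoromethyl at this position gives a change beyond the scatter, though a modest one. The earlier swap at this position, a 1.8-fold higher number from compound 2 to compound 3 (0.25 log units; within the scatter), showed no such separation, and it was read on a pair with a configuration drawn and with a different fluoroalkyl chain. No measurement at hand offers a reason for the new step.

On these data alone, whether a plain ethoxy or a 2-hydroxyethoxy group at the same place would read like 2-fluoroethoxy remains open, which leaves the share of the fluorine itself unsettled. Also open, as far as these compounds go, is how compound 4 would read with a defined configuration at the saturated ring carbon.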